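A few compounds are considered here, and "the series" means these few. Any claim that something is new, unique, unknown or untested is made for them only; others in the source may bear on it.

Three compounds share one core and differ only in the group attached to the carbonyl carbon. Compound 1 `CCNC(=O)c1cc(N)c(Nc2ccc(C#N)cc2)cc1Oc1c(C)cc(/C=C/C#N)cc1C` gives 69.4 ug/mL in a physicochemical assay for solubility, read by HPLC, with a stated time of 4 h, at pH 2; a higher number here means a more soluble compound, a lower number a less soluble compound. Compound 2 `Cc1cc(/C=C/C#N)cc(C)c1Oc1cc(Nc2ccc(C#N)cc2)c(N)cc1C(=O)N1CC1` gives 94.2 ug/mL. Compound 3 `COC(=O)c1cc(N)c(Nc2ccc(C#N)cc2)cc1Oc1c(C)cc(/C=C/C#N)cc1C` gives 21.8 ug/mL. Compound 3 stands lowest of the three, since a 3.2-fold lower number from compound 1 to compound 3 (0.50 log units; beyond the scatter) and a 4.3-fold lower number from compound 2 to compound 3 (0.64 log units; beyond the scatter), while a 1.4-fold higher number from compound 1 to compound 2 (0.13 log units; within the scatter). Compound 4 `Cc1cc(/C=C/C#N)cc(C)c1Oc1cc(Nc2ccc(C#N)cc2)c(N)cc1C(=O)OCCC#N` is compound 3 with cyanomethyl in place of hydrogen on a saturated chain carbon bound to an oxygen next to a carbonyl group. Among the compounds with values here, none of the measured steps extends a chain in this way; they only show that methoxycarbonyl sits lowest. With no direct guide, the expectation for compound 4 is a 1.1-fold higher number from compound 3 to compound 4 (0.06 log units; within the scatter), a step not beyond the scatter. Compound 4 is therefore estimated at 25 ug/mL, with a range from 10 ug/mL to 60 ug/mL.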

Compound 4, solubility: 0.94 ug/mL
Beside the measured number, compound 4's estimate is 27-fold (1.42 log units) above it, outside the stated range (below it).
By their numbers in this assay, from the lowest: compound 4; then compound 3; then compounds 1 and 2 (each within the scatter of the next).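

Lengthening methoxy to 2-cyanoethoxy in this assay moves the number far more (a 23-fold lower number from compound 3 to compound 4 (1.37 log units; beyond the scatter)) than any swap among the earlier compounds, so a change at the outer end of this group, away from the carbonyl carbon, can count heavily. The gaps to the compounds carrying ethylamino (a 74-fold lower number from compound 1 to compound 4 (1.87 log units; beyond the scatter)) and aziridin-1-yl (a 100-fold lower number from compound 2 to compound 4 (2.00 log units; beyond the scatter)) are wider still. No measurement offered here accounts for this drop.

As far as these compounds go, whether the nitrile or the added chain length carries the step remains open. So does what an ethoxy group or a carboxylic acid on the carbonyl carbon would give.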